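Trimming one ester chain on compound 3

The compounds below may be only part of what the source reports. "The series", "measured", "known", "first", "only" and "open" are said of these compounds alone.

Measured in a functional assay on A549 cells (Homo sapiens) for inhibition, read by MTT assay, with a stated time of 24 h; a higher number here means a weaker inhibitor, a lower number a stronger inhibitor:
- Compound 1 `C/C=C(\C)C(=O)O[C@@H]1C(=O)/C=C2/C3=CC(=O)O[C@@H](c4ccoc4)[C@]3(C)CC[C@@H]2[C@@]2(C)C(=O)C[C@]1(C)[C@@H]2[C@@H](O)C(=O)OC`: > 100000 nM, a limit and not a number
- Compound 2 `C/C=C(\C)C(=O)O[C@@H]1[C@]2(OC(=O)CCCC)C=C3C4=CC(=O)O[C@@H](c5ccoc5)[C@]4(C)CC[C@@H]3[C@@]3(C)[C@H](C[C@]1(C)[C@H]3[C@@H](OC(=O)CCCC)C(=O)OC)O2`: 5500 nM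
- Compound 3 `C/C=C(\C)C(=O)O[C@@H]1[C@]2(OC(=O)CCCC)C=C3C4=CC(=O)O[C@@H](c5ccoc5)[C@]4(C)CC[C@@H]3[C@@]3(C)[C@H](C[C@]1(C)[C@H]3[C@@H](O)C(=O)OC)O2`: 9400 nM

Compound 1 gives only a limit, (the limit of > 100000 nM in this assay, at which 1 of the 3 values shown sits). Among the compounds with values here, compound 3 shows 9400 nM, and the only measured step that reaches it is a 1.7-fold higher number from compound 2 to compound 3 (0.23 log units; within the scatter). That step took away a whole butylcarbonyl, yet compound 3 keeps a second butylcarbonyl, and this is the group changed next.

Compound 4 `C/C=C(\C)C(=O)O[C@@H]1[C@]2(OC(=O)CC)C=C3C4=CC(=O)O[C@@H](c5ccoc5)[C@]4(C)CC[C@@H]3[C@@]3(C)[C@H](C[C@]1(C)[C@H]3[C@@H](O)C(=O)OC)O2` differs from compound 3 in one place: hydrogen in place of ethyl on a saturated chain carbon, two bonds along the chain from a carbonyl carbon. Hydrogen stands in place of ethyl on a saturated chain carbon, two bonds along the chain from a carbonyl carbon, so butylcarbonyl becomes propanoyl.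

Within the data shown here, this is a smaller change than the loss of a whole butylcarbonyl, though at another place, and no measured step tests this chain directly. No step beyond the scatter is therefore expected in this assay. The expected step is a 1.1-fold higher number from compound 3 to compound 4 (0.03 log units; within the scatter). The estimate for compound 4 is 10000 nM, with an expected range from 4500 nM to 22000 nM.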

Compound 4, half-maximal inhibitory concentration: > 100000 nM
Compound 4 ended at the assay's limit; the forecaster's own chance of this, stated with the estimate: 5%; middle value at least 10-fold (1.00 log units) away from the limit.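

Cutting butylcarbonyl down to propanoyl removes only an ethyl, yet it gives an at least 10-fold higher number from compound 3 to compound 4 (1.02 log units; beyond the scatter) in this assay. The whole butylcarbonyl lost in the earlier step, a 1.7-fold higher number from compound 2 to compound 3 (0.23 log units; within the scatter), made far less difference, so in this series the effect of trimming an ester chain depends strongly on which chain is trimmed, and here the exact chain length matters a great deal. For compound 4 the reading of > 100000 nM is a limit and not a number, and two compounds now stand there: the limit of > 100000 nM in this assay, at which 2 of the 4 values shown sit.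

From the compounds shown here alone, what a longer chain such as hexanoyl, or a shorter one such as acetyl, would do at this place remains open. Also open, going by these compounds, is whether the same trim would matter as much in compound 2, which keeps both butylcarbonyl groups.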